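The source may hold more compounds than are shown below. What is called first, only, known or untested is meant among the compounds shown, and "the series" means these compounds.

Compound 1 `Cc1cccc(/C(N)=N/NC(=S)N2CCCCC2)n1`: 76.4%
Compound 2 `N/C(=N\NC(=S)N1CCOCC1)c1ccccn1`: 18.3%

Among the measured compounds shown here, in a functional assay on A-375 cells (Homo sapiens) for cytotoxicity, read by MTT assay, with a stated time of 72 h, tested at 10 uM (a lower number here means less inhibition of growth, a higher number more inhibition of growth at the concentration tested), compound 2 gives 18.3%, the lowest of the two numbers measured so far. Compound 1 gives 76.4%, a number far above it and well beyond the scatter. Compound 1 and compound 2 differ in two places, so their gap cannot be assigned to either change on its own.

Compound 3 `Cc1cccc(/C(N)=N/NC(=S)N2CCOCC2)n1` has not yet been measured in this assay. It differs from compound 2 by one change: methyl in place of hydrogen on an aromatic carbon. For the measured compounds named here, the only measured compound carrying that methyl, compound 1, also carries a different ring on the thiourea, so the two numbers give no clean guide to the methyl alone. Compound 3 is therefore expected at about 40%, within 15% to 70%. The expected step of a number 21.7 percentage points higher from compound 2 to compound 3 (beyond the scatter) is upward but uncertain, and could fall within the scatter.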

Compound 3, percent growth inhibition at one concentration: 43.6%
Beside the measured number, compound 3's estimate is 3.6 percentage points below it; measured number inside the range.
By their numbers in this assay, from the lowest: compound 2; then compound 3; then compound 1.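

In this assay, methyl in place of hydrogen on the aromatic carbon next to the ring nitrogen can now be read on its own, with the morpholin-4-yl group held fixed: the change gives a number 25.3 percentage points higher from compound 2 to compound 3 (beyond the scatter). With the methyl held fixed, morpholin-4-yl in place of piperidin-1-yl on the thiocarbonyl carbon can also be read, and it gives a number 32.8 percentage points lower from compound 1 to compound 3 (beyond the scatter), so each of the two changes separating the earlier pair moves the number beyond the scatter on its own. Nothing available explains either step.

The compounds shown leave open whether the methyl step would hold with piperidin-1-yl on the thiocarbonyl carbon, as no compound pairs that group with hydrogen at this position. They also leave open how an ethyl group or a chlorine atom would read at this position, or a dimethylamino group on the thiocarbonyl carbon.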